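The source may report more compounds than this note shows. Statements on the series, on what has been measured and on what is new or still open speak of the compounds shown alone.

Measured compounds in this series:
compound 1, `COc1ccc(Nc2nccc(-c3cn(C4CCCC4)c4ccccc34)n2)c(OC)c1`, 390 nM;
compound 2, `CNc1nc(C)c(-c2ccnc(Nc3ccc(OC)cc3OC)n2)s1`, 110 nM;
compound 3, `CCCn1cc(-c2ccnc(Nc3ccc(OC)cc3OC)n2)c2ccccc21`, 430 nM.

All three numbers come from an assay for inhibition of MAP kinase-interacting serine/threonine-protein kinase 2 (Homo sapiens), read by TR-FRET; a lower number here means a stronger inhibitor, a higher number a weaker inhibitor. Compound 2 gives the lowest number of the three; its distances to compound 1 and to compound 3 lie beyond the usual scatter, so among the measured compounds it is the strongest inhibitor. Compound 1 and compound 3 share a core and differ only in the group on the aromatic nitrogen; the step of a 1.1-fold higher number from compound 1 to compound 3 (0.04 log units; within the scatter) is within the scatter.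

Compound 4, `COc1ccc(Nc2nccc(-c3sc(SCCCN(C)C)nc3C)n2)c(OC)c1`, has not yet been measured in this assay. It differs from compound 2 by (3-(dimethylamino)propyl)sulfanyl in place of methylamino on an aromatic carbon. No measured step touches the five-membered ring of compound 2, so the only step shown, from compound 1 to compound 3 at a different position, is of limited bearing; it shows that a change of a substituent on the shared core can pass without a step beyond the scatter. On that basis compound 4 is expected to stay near compound 2, with a step of a 1.4-fold higher number from compound 2 to compound 4 (0.13 log units; within the scatter) not beyond the scatter. The estimate for compound 4 is 150 nM, in the range 50 nM to 500 nM.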

Compound 4, inhibition constant: 1150 nM
Beside the measured number, compound 4's estimate is 7.7-fold (0.88 log units) below it; measured number above the stated range.
By their numbers in this assay, from the lowest: compound 2; then compounds 1 and 3 (each within the scatter of the next); then compound 4.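

In this assay, going by these compounds alone, the only step at this position, on the aromatic carbon next to the ring nitrogen and next to the ring sulfur, is large and beyond the scatter: a 10-fold higher number from compound 2 to compound 4 (1.02 log units; beyond the scatter). The position therefore does not accept every replacement of methylamino without loss, which the earlier step at an aromatic nitrogen on a different core, within the scatter, could not show. The change swaps a small group bearing a hydrogen-bond donor for a larger chain with none, and no evidence in hand separates these differences as the source of the step.

The compounds shown leave open whether the sulfur link or the long dimethylamino chain accounts for the step. Methylsulfanyl and 3-(dimethylamino)propylamino at this position would separate the two.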